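Flavone Series: A Dihydroxypropoxy Group at the Open Position

The source may hold more compounds than are shown below. What is called first, only, known or untested is meant among the compounds shown, and "the series" means these compounds.

Compound 1, `CCOC(=O)COc1ccc2c(=O)cc(-c3cc(C(C)(C)C)c(O)c(C(C)(C)C)c3)oc2c1`, in a functional assay for inhibition (on this read-out higher numbers stand for weaker inhibition and lower numbers for stronger inhibition), gives 3000 nM.
Compound 2, `CC(C)(C)c1cc(-c2cc(=O)c3ccccc3o2)cc(C(C)(C)C)c1O`, in this assay gives 3000 nM.

Compound 2 stands level with compound 1 at the digits shown; the only step recorded, no change at the digits printed from compound 1 to compound 2 (within the scatter), left the read-out unchanged within the scatter. Compound 3, `CC(C)(C)c1cc(-c2cc(=O)c3ccc(OCC(O)CO)cc3o2)cc(C(C)(C)C)c1O`, is not yet measured. It differs from compound 2 by 2,3-dihydroxypropoxy in place of hydrogen on an aromatic carbon, at the same aromatic carbon where compound 1 carries its (ethoxycarbonyl)methoxy group. That one step bears directly on the change, and it was flat. Compound 3 is therefore expected to show no change at the digits printed from compound 2 to compound 3 (within the scatter) in this assay, no step beyond the scatter, because the removal of the earlier group gave no change at the digits printed from compound 1 to compound 2 (within the scatter). Compound 3 is estimated at 3000 nM, within 1000 nM to 9000 nM.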

Compound 3, half-maximal inhibitory concentration: 100 nM
Beside the measured number, compound 3's estimate is 30-fold (1.48 log units) above it, outside the stated range (below it).
By their numbers in this assay, from the lowest: compound 3; then compounds 1 and 2 (each within the scatter of the next).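

In this assay, the open position proves responsive to what it carries: 2,3-dihydroxypropoxy in place of hydrogen gives a 30-fold lower number from compound 2 to compound 3 (1.48 log units; beyond the scatter), a step beyond the scatter. The (ethoxycarbonyl)methoxy group on the same aromatic carbon had given no such difference, whereas 1,2-dihydroxyethyl in place of its ethoxycarbonyl gives a 30-fold lower number from compound 1 to compound 3 (1.48 log units; beyond the scatter). The earlier flat step therefore described one substituent rather than the position as a whole, and among these compounds the outcome depends on what the oxygen-linked chain carries, not on the presence of such a chain alone.

Nothing available explains the size of this step. On these data alone, whether both hydroxyl groups are needed stays open, as does whether 2-hydroxyethoxy, a longer chain, an amine or a carboxylic acid at this position would match compound 3.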